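A few compounds are considered here, and "the series" means these few. Any claim that something is new, unique, unknown or untested is made for them only; others in the source may bear on it.

Of the compounds shown here, three built on a shared core have been tested in a functional assay on MGC-803 cells (Homo sapiens) for inhibition, read by MTT assay, with a stated time of 72 h; a higher number here means a weaker inhibitor, a lower number a stronger inhibitor. Compound 1 `Cc1cc(N2CC[C@@H](C)[C@@H](N(C)c3ncnc4[nH]ccc34)C2)n2ncnc2n1` gives 4350 nM. Compound 2 `Cc1cc(N2CC[C@@H](C)[C@@H](N(C)c3ncnc4[nH]ccc34)C2)n2nc(SCc3ccc(C(F)(F)F)cc3)nc2n1` gives 2680 nM. Compound 3 `Cc1cc(N2CC[C@@H](C)[C@@H](N(C)c3ncnc4[nH]ccc34)C2)n2nc(SCc3ccc(Cl)cc3)nc2n1` gives 16000 nM. Among the compounds with values here, of these three numbers, compound 2 has the lowest, yet the step of a 1.6-fold lower number from compound 1 to compound 2 (0.21 log units; within the scatter) lies within the scatter, so compound 1 and compound 2 cannot be told apart; only the steps of a 3.7-fold higher number from compound 1 to compound 3 (0.57 log units; beyond the scatter) and a 6.0-fold higher number from compound 2 to compound 3 (0.78 log units; beyond the scatter) are beyond it.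

Compound 4 `COc1ccc(CSc2nc3nc(C)cc(N4CC[C@@H](C)[C@@H](N(C)c5ncnc6[nH]ccc56)C4)n3n2)cc1` has not yet been measured. It differs from compound 2 in one place: methoxy in place of trifluoromethyl on an aromatic carbon. Within the data shown here, the only measured step that touches this same place is a 6.0-fold higher number from compound 2 to compound 3 (0.78 log units; beyond the scatter), a modest move toward weaker inhibition. Among the measured compounds shown here, no compound carrying methoxy at that place has been measured, so the expectation rests on that single step and is loose. A modest rise in the number is therefore expected, a 3.0-fold higher number from compound 2 to compound 4 (0.47 log units; beyond the scatter). For compound 4 the estimated value in this assay is 8000 nM, with a range from 2500 nM to 25000 nM.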

Compound 4, half-maximal inhibitory concentration: 15200 nM
The estimate for compound 4 lay 1.9-fold (0.28 log units) below the measured number, and the stated range covers the measured number.
By their numbers in this assay, from the lowest: compounds 2 and 1 (each within the scatter of the next); then compounds 4 and 3 (each within the scatter of the next).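

In this assay, replacing trifluoromethyl on the aromatic ring a second time again gives weaker inhibition (a 5.7-fold higher number from compound 2 to compound 4 (0.75 log units; beyond the scatter)), while methoxy and chloro cannot be told apart (a 1.1-fold lower number from compound 3 to compound 4 (0.02 log units; within the scatter)). Trifluoromethyl now stands apart from two different groups at this place, and adding the whole (4-methoxybenzyl)sulfanyl group to the core of compound 1 also gives weaker inhibition (a 3.5-fold higher number from compound 1 to compound 4 (0.54 log units; beyond the scatter)), whereas the (4-(trifluoromethyl)benzyl)sulfanyl group shifts the number only within the scatter. Nothing measured here explains this difference between the groups.

From the compounds shown here alone, it remains open whether trifluoromethyl is unusual here or whether a nitrile, a fluoro or an amine at the same place would also keep the number low. Also open, going by these compounds, is how the result would change with a longer chain between the sulfur and the aromatic ring.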